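A few compounds are considered here, and "the series" means these few. Any claim that something is new, unique, unknown or untested is made for them only; others in the source may bear on it.

Of the compounds shown here, two of this set have been tested so far, both carrying the same trimethoxyphenyl-pyrazole core and differing in what hangs from the ethenyl arm. Compound 1 `COc1cc(-c2cc(/C=C/C(C)=O)[nH]n2)cc(OC)c1OC` ends in a simple methyl ketone, and in a functional assay on MCF7 cells (Homo sapiens) for inhibition, read by MTT assay, with a stated time of 48 h (a higher number here means a weaker inhibitor, a lower number a stronger inhibitor), compound 1 gives 20100 nM. Compound 2 `COc1cc(-c2cc(/C=C3\Cc4ccccc4C3=O)[nH]n2)cc(OC)c1OC` closes that ketone into a fused two-ring system, and in this assay compound 2 gives 4800 nM. On these two numbers compound 2 stands lowest, and its gap to compound 1 lies beyond the usual scatter, so compound 2 is the stronger inhibitor of the pair.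

Compound 3 `COc1ccc2c(c1)C/C(=C\c1cc(-c3cc(OC)c(OC)c(OC)c3)n[nH]1)C2=O` keeps everything in compound 2 and adds one small group: methoxy in place of hydrogen on an aromatic carbon. Among the compounds with values here, no step of this kind has yet been measured here, so the direction of the change rests on expectation alone. With only the shift from compound 1 to compound 2 to go by, a step from compound 2 to compound 3 is expected to stay small, a 1.2-fold lower number from compound 2 to compound 3 (0.08 log units; within the scatter), likely within the scatter and without a clear direction. Compound 3 is therefore estimated at 4000 nM in this assay, within a range of 1500 nM to 12000 nM.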

Compound 3, half-maximal inhibitory concentration: 2100 nM
For compound 3 the middle estimate is 1.9-fold (0.28 log units) above the measured one; low and high end bracket the measured number.
By their numbers in this assay, from the lowest: compound 3; then compound 2; then compound 1.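

In this assay, methoxy in place of hydrogen on an aromatic carbon of the six-membered ring within the fused system gives a 2.3-fold lower number from compound 2 to compound 3 (0.36 log units; beyond the scatter). Within the data shown here, this is the first measured change at this spot, and although the step is modest, it lies beyond the usual scatter: this carbon can carry a group larger than hydrogen without loss of inhibition, and here the inhibition becomes stronger. Nothing measured alongside these numbers explains why the step goes in this direction.

A single step cannot show whether the gain belongs to methoxy itself or would also appear with another group on the same carbon, such as a hydroxyl, a fluorine atom or the longer ethoxy group. It also leaves open whether methoxy on a different carbon of that ring would give a similar shift, and whether a second methoxy on the same ring would add to it or cancel it.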